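The compounds below may be only part of what the source reports. "The series", "measured", "known", "first", "only" and "open" are said of these compounds alone.

Measured compounds:
- compound 1 `CCCCC(CC)C(=O)Nc1ccc2ccn(Cc3ccc(C(=O)NS(=O)(=O)c4ccc(F)cc4)cc3OC)c2c1`: 7.7
- compound 2 `COc1cc(C(=O)NS(=O)(=O)c2cc(C)ccc2C)ccc1Cn1ccc2ccc(NC(=O)CC3CCCC3)cc21`: 8.4

Both compounds were tested in a functional assay (trachea) for antagonist activity, with Cavia porcellus as the target; on this read-out lower numbers stand for lower potency and higher numbers for higher potency (the scale is a negative logarithm). Compound 2 gives the higher of the two numbers, with compound 1 standing lower by a gap that lies beyond the usual scatter of repeated measurements. The two compounds differ in more than one place, so their values alone cannot be tied to any single change.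

The next compound, compound 3 `COc1cc(C(=O)NS(=O)(=O)c2cccs2)ccc1Cn1ccc2ccc(NC(=O)CC3CCCC3)cc21`, has not yet been measured in this assay. It departs from compound 2 in one place: thiophen-2-yl in place of 2,5-dimethylphenyl on a sulfonyl sulfur. The new group is smaller and carries one hydrogen-bond acceptor where the old one had none.

Among the measured compounds shown here, no measured pair shows what such a change does here, so any expectation rests on the two values alone. The step is expected to be modest and, if anything, downward, and it may well stay within the scatter: the expected step is a number 0.40 log units lower from compound 2 to compound 3 (beyond the scatter). For compound 3 the estimate is 8, with a range from 7.4 to 8.6.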

Compound 3, negative logarithm of the antagonist equilibrium constant: 9.6
Compound 3: middle estimate off by 1.60 log units, on the low side; measured number outside the range, above it.
By their numbers in this assay, from the lowest: compound 1; then compound 2; then compound 3.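

In this assay, exchanging 2,5-dimethylphenyl for thiophen-2-yl on the sulfonyl sulfur gives a number 1.20 log units higher from compound 2 to compound 3 (beyond the scatter), a large gain with the rest of the molecule held constant. Among the compounds shown here, this is the first direct evidence that the group on the sulfonyl sulfur can strongly shift this read-out, and that the 2,5-dimethylphenyl ring is not needed to reach a high number, since the smaller five-membered ring with one sulfur atom outperforms it here. Nothing measured on these compounds accounts for the size of the step, so it stands as an observation without an explanation.

For the compounds shown here, the single step changes ring size, the ring hetero atom and the two methyl groups all at once, so it cannot say which of these matters; plain phenyl would test the loss of the methyl groups, and furan-2-yl would test the exchange of the ring sulfur for oxygen. Compound 1 differs from compound 2 and compound 3 in more than one place, so it does not show whether the same gain would hold with a different acyl group on the amide of the core.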